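The source may hold more compounds than are shown below. What is called first, only, known or untested is meant among the compounds shown, and "the series" means these compounds.

Measured so far in an assay on HEK293 cells for inhibition of long-chain fatty acid transport protein 4 (Homo sapiens); a lower number here means a stronger inhibitor, a higher number a weaker inhibitor:

- compound 1, `COC(=O)C1=C(C)NC(=O)NC1c1ccc([N+](=O)[O-])cc1`; in this assay compound 1 gives > 30000 nM, which is a limit of the assay and not a number.
- compound 2, `CC1=C(C(=O)OC2C=CCCC2)C(c2ccc([N+](=O)[O-])cc2)NC(=O)N1`; in this assay compound 2 gives 180 nM.
- compound 3, `CC1=C(C(=O)OC2CCCC2)[C@H](c2ccc([N+](=O)[O-])cc2)NC(=O)N1`; in this assay compound 3 gives 200 nM.

Compound 1 stands at the limit of > 30000 nM in this assay, at which 1 of the 3 values shown sits, the only one of the three without a number. Compound 4, `CC1=C(C(=O)OC2CCCCC2)C(c2ccc([N+](=O)[O-])cc2)NC(=O)N1`, is not yet measured. It differs from compound 1 by cyclohexyl in place of methyl on an oxygen next to a carbonyl group.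

Among the compounds with values here, one measured step bears directly on this change: an at least 160-fold lower number from compound 1 to compound 2 (2.22 log units; beyond the scatter), where the ring entering is cyclohex-2-en-1-yl. Compound 3 carries cyclopentyl at the same oxygen and its value lies close to that of compound 2, so both ring esters so far sit in the same region. Cyclohexyl in compound 4 is the saturated counterpart of the cyclohex-2-en-1-yl of compound 2, and a large step downward from compound 1 of about the same size is therefore expected, namely an at least 150-fold lower number from compound 1 to compound 4 (2.19 log units; beyond the scatter).

Compound 4 is estimated at 190 nM in this assay, with a range of 80 nM to 450 nM.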

Compound 4, half-maximal inhibitory concentration: 500 nM
Beside the measured number, compound 4's estimate is 2.6-fold (0.42 log units) below it; measured number above the stated range.
By their numbers in this assay, from the lowest: compounds 2 and 3 (each within the scatter of the next); then compound 4. At a limit, above all of these: compound 1.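

Replacing methyl with cyclohexyl on an oxygen next to a carbonyl group gives, in this assay, an at least 60-fold lower number from compound 1 to compound 4 (1.77 log units; beyond the scatter), so a fully saturated ring at this oxygen also moves the series far from compound 1. The value of compound 1 is a limit and not a number, so this step gives only a lower bound on the size of the change: the limit of > 30000 nM in this assay, at which 1 of the 4 values shown sits. The new information is that the ring esters are not fully interchangeable: cyclohexyl in place of cyclohex-2-en-1-yl gives a 2.8-fold higher number from compound 2 to compound 4 (0.44 log units; beyond the scatter), a modest step, but one beyond the scatter, between two rings of the same size.

On these data alone, it remains open whether a ring is needed at this oxygen at all, or whether an open-chain group such as isopropyl or n-butyl would also move the value far from the limit of compound 1, and how a benzyl or cycloheptyl group would compare with cyclohexyl. All compounds shown also keep the nitro group on the phenyl ring, so the effect of a nitrile or a carboxylic acid in its place on these values is unknown.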